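Pyridin-2-yl to pyridin-3-yl on the shared core

The source may report more compounds than this note shows. Statements on the series, on what has been measured and on what is new or still open speak of the compounds shown alone.

Measured in an ADME assay on microsomes (Mus musculus) for metabolic stability; a lower number here means slower removal, a higher number faster removal of the compound:
- compound 1 `CNC(=O)[C@@H]1CCCN1S(=O)(=O)c1ccc(Cl)c(COc2cccc3c(-n4ccnc4)cc(C)nc23)c1Cl`: 267 mL/min/kg
- compound 2 `CNC(=O)[C@@H]1CCCN1S(=O)(=O)c1ccc(Cl)c(COc2cccc3c(-c4ccccn4)cc(C)nc23)c1Cl`: 733 mL/min/kg

Compound 2 is the higher of the two numbers, at 733 mL/min/kg. Going by the values given here, the one measured step is a 2.7-fold higher number from compound 1 to compound 2 (0.44 log units; beyond the scatter), with pyridin-2-yl in place of 1H-imidazol-1-yl on an aromatic carbon. It is modest but beyond the scatter.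

Compound 3 `CNC(=O)[C@@H]1CCCN1S(=O)(=O)c1ccc(Cl)c(COc2cccc3c(-c4cccnc4)cc(C)nc23)c1Cl` differs from compound 2 as follows: pyridin-3-yl in place of pyridin-2-yl on an aromatic carbon. Here pyridin-3-yl stands in place of pyridin-2-yl, opposite the ring nitrogen. Among the compounds with values here, no measured compound carries pyridin-3-yl, so the evidence is thin. Within the data shown here, the one measured step, a 2.7-fold higher number from compound 1 to compound 2 (0.44 log units; beyond the scatter), exchanged one ring for a different ring and serves only as an upper guide to size. A smaller change is expected in this assay, leaning lower and probably within the scatter, as a 1.5-fold lower number from compound 2 to compound 3 (0.18 log units; within the scatter) expresses. For compound 3 the estimated clearance is 480 mL/min/kg, with an expected range of 230 mL/min/kg to 900 mL/min/kg.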

Compound 3, clearance: 700 mL/min/kg
The estimate for compound 3 lay 1.5-fold (0.16 log units) below the measured number; the range from low to high includes it.
By their numbers in this assay, from the lowest: compound 1; then compounds 3 and 2 (each within the scatter of the next).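

In this assay, pyridin-3-yl in place of pyridin-2-yl on this aromatic carbon gives a 1.0-fold lower number from compound 2 to compound 3 (0.02 log units; within the scatter) and so no readable change: moving the pyridine attachment does not separate these two compounds. Pyridin-3-yl in place of 1H-imidazol-1-yl gives a 2.6-fold higher number from compound 1 to compound 3 (0.42 log units; beyond the scatter) and thus matches what compound 2 showed, with compound 1 standing apart from both pyridine compounds. Nothing available bears on what lies behind these numbers.

Going by these compounds, it remains open whether pyridin-4-yl, phenyl or a saturated amine such as morpholine at this position would group with compound 1 or with compound 2 and compound 3. Also open, on these data alone, is whether these steps would hold with a carboxylic acid in place of the methylamide on the shared core.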